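Methyl on the Phenyl Ring Across Two Thiazolidinone Cores

The compounds below may be only part of what the source reports. "The series", "measured", "known", "first", "only" and "open" are said of these compounds alone.

Compound 1 `O=C1N/C(=N/c2csc(-c3ccc(Cl)cc3)c2)S/C1=C\c1ccccc1` was examined in a functional assay on MCF7 cells (Homo sapiens) for cytotoxicity, read by MTT assay, with a stated time of 72 h; a higher number here means a weaker inhibitor, a lower number a stronger inhibitor. For compound 1 the result is only a limit, > 50000 nM. Compound 2 `Cc1ccc(/C=C2\S/C(=N\c3csc(-c4ccc(Cl)cc4)c3)NC2=O)cc1` differs from it by methyl in place of hydrogen on an aromatic carbon. In this assay compound 2 gives 900 nM, and the step of an at least 55-fold lower number from compound 1 to compound 2 (1.74 log units; beyond the scatter) is large. Its true size is not fixed, because one end rests on (the limit of > 50000 nM in this assay, at which 1 of the 3 values shown sits). Compound 3 `COc1cccc(N2C(=O)CS/C2=N\c2csc(-c3ccccc3)c2)c1` sits on another core; how that core differs from the core of compound 1 is not broken down here. In this assay compound 3 has "not determined" (no result reported), so no result is reported for it. Compound 4 `COc1cccc(N2C(=O)CS/C2=N\c2csc(-c3ccc(C)cc3)c2)c1` differs from compound 3 by methyl in place of hydrogen on an aromatic carbon, the same change that separates compound 1 from compound 2. He expects the methyl to move compound 4 toward a lower number than compound 3 in this assay, a direction that rests on the single pair an at least 55-fold lower number from compound 1 to compound 2 (1.74 log units; beyond the scatter), yet with compound 3 unmeasured and compound 1 at a limit, the size of the expected step is open. For compound 4 in this assay he estimates 6000 nM, with a likely range from 800 nM to 50000 nM.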

Compound 4, half-maximal inhibitory concentration: > 50000 nM
Compound 4 gave a limit, no number; the forecaster's own chance of this, stated with the estimate: 35%; at least 8.3-fold (0.92 log units) between middle value and limit.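

In this assay compound 4 gives > 50000 nM, which is a limit and not a number. With no number for compound 3 either, no step can be read between compound 3 and compound 4. The compounds shown leave open whether methyl in place of hydrogen on an aromatic carbon changes the result on the core of compound 3 as it does on the core of compound 1.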